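Cytotoxicity limits across three compounds and one estimate

A few compounds are considered here, and "the series" means these few. Any claim that something is new, unique, unknown or untested is made for them only; others in the source may bear on it.

The measured compounds are:
compound 1, `CC(/C=N/Nc1ccc([N+](=O)[O-])cc1)=N\NC(=O)c1ccccc1Cl`: in an ADME assay on J774 cells (Mus musculus, strain BALB/c) for cytotoxicity, read by resazurin assay, with a stated time of 72 h (a higher number here means that more compound is tolerated, a lower number that less compound is tolerated), compound 1 gives > 100000 nM, a limit of the assay.
compound 2, `CC(/C=N/Nc1ccc([N+](=O)[O-])cc1)=N\NC(=O)c1ccccc1F`: in this assay compound 2 gives > 100000 nM, a limit.
compound 3, `CC(/C=N/Nc1ccc([N+](=O)[O-])cc1)=N\NC(=O)c1ccccc1C`: in this assay compound 3 gives > 100000 nM, a limit.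

Compound 3 therefore stands where every measured value stands, at the limit of > 100000 nM in this assay, at which 3 of the 3 values shown sit. The three steps among these compounds, a step that the two limits leave unreadable from compound 1 to compound 2, a step that the two limits leave unreadable from compound 1 to compound 3 and a step that the two limits leave unreadable from compound 2 to compound 3, are unreadable in size for the same reason, so none of them tells how far tolerance actually extends in either direction.

Compound 4, `COc1cc(C(=O)N/N=C(C)/C=N/Nc2ccc([N+](=O)[O-])cc2)ccc1O`, differs from compound 3 by 4-hydroxy-3-methoxyphenyl in place of 2-methylphenyl on a carbonyl carbon. Among the compounds with values here, no measured step involves a change at this carbonyl carbon of comparable kind, so the measured steps give no size to carry over; they show only that compound 3 sits at the limit. On that basis compound 4 is expected to sit at the limit as well, with an expected step that the limit leaves unreadable from compound 3 to compound 4, nothing beyond the scatter. The estimate for compound 4 in this assay is 150000 nM, with a range from 60000 nM to 400000 nM.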

Compound 4, half-maximal cytotoxic concentration: > 100000 nM
Compound 4: no number, only a limit (the forecaster's own chance of this, stated with the estimate: 80%); the middle value lies beyond the limit too.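

Compound 4 also sits at a limit, so no step from compound 1, compound 2 or compound 3 to compound 4 can be read: the limit of > 100000 nM in this assay, at which 4 of the 4 values shown sit.

The compounds shown leave open at what concentration any of them becomes cytotoxic in this assay, and whether these changes alter that concentration.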